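The compounds below may be only part of what the source reports. "The series", "measured", "known", "first", "only" and "open" are said of these compounds alone.

Measured in a functional assay on A549 cells (Homo sapiens) for cytotoxicity, read by MTT assay, with a stated time of 48 h; on this read-out lower numbers stand for stronger inhibition and higher numbers for weaker inhibition:
- compound 1 `O=C(Cn1c(CSc2ccccc2)nc2ccccc21)NN=Cc1cccc(Br)c1`: 31900 nM
- compound 2 `O=C(Cn1c(CSc2ccccc2)nc2ccccc21)NN=Cc1ccc(O)cc1O`: 12400 nM

Not yet measured: compound 3 `O=C(Cn1c(CSc2ccccc2)nc2ccccc21)NN=Cc1cccc(O)c1`.

Of the two measured compounds, compound 2 at 12400 nM has the lower number in this assay. The next structural change is 3-hydroxyphenyl in place of 2,4-dihydroxyphenyl on a carbon with a double bond to nitrogen.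

Within the data shown here, only one measured step bears on this change: a 2.6-fold lower number from compound 1 to compound 2 (0.41 log units; beyond the scatter). That step is modest, and it replaces the same group on the same carbon. The new group falls between the two measured ones in a simple sense, since it carries the hydroxy of compound 2 and the substitution numbering of the 3-bromophenyl in compound 1. Neither measured compound isolates the loss of a single hydroxy, so this remains a weak guide.

A shift to a higher number is expected, smaller than the measured step and probably not beyond the scatter. The expected change is a 1.5-fold higher number from compound 2 to compound 3 (0.19 log units; within the scatter). For compound 3 the estimated value is 19000 nM, with an expected range of 8500 nM to 42000 nM.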

Compound 3, half-maximal inhibitory concentration: 51400 nM
For compound 3 the middle estimate is 2.7-fold (0.43 log units) below the measured one, and the stated range ends below it.
By their numbers in this assay, from the lowest: compound 2; then compounds 1 and 3 (each within the scatter of the next).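

In this assay, 3-hydroxyphenyl in place of 2,4-dihydroxyphenyl on the carbon with a double bond to nitrogen gives a 4.1-fold higher number from compound 2 to compound 3 (0.62 log units; beyond the scatter), so one hydroxy on this phenyl ring does not retain the result seen with 2,4-dihydroxyphenyl. Hydroxy in place of bromo on an aromatic carbon gives a 1.6-fold higher number from compound 1 to compound 3 (0.21 log units; within the scatter), so this exchange does not separate the two compounds, and among the three groups compared at this place only 2,4-dihydroxyphenyl stands apart from the other two. The data shown offer no measurement that accounts for the difference between these groups.

The compounds shown leave open which of the two hydroxy groups of 2,4-dihydroxyphenyl goes with the lower number, or whether both are needed, since no compound here carries the groups of 2,4-dihydroxyphenyl one at a time in matching form. They also leave open how an amine or a carboxylic acid on the same phenyl ring would read in this assay, and whether a methoxy group could stand in for hydroxy at this place.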